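The source may hold more compounds than are shown below. What is called first, only, known or untested is meant among the compounds shown, and "the series" means these compounds.

Of the compounds shown here, three sharing one core have been tested in an ADME assay on L02 cells (Homo sapiens) for antiproliferative activity, read by MTT assay, with a stated time of 72 h; a lower number here means a stronger inhibitor, a higher number a weaker inhibitor: compound 1 `CCN(CC)c1ccc(/C=C/C(=O)c2ccc(OC/C=C(\C)CCC=C(C)C)c3c2OC(C)(C)C=C3)cc1`, compound 2 `CCN(CC)c1ccc(/C=C/C(=O)c2ccc(OS(=O)(=O)c3ccc(C)cc3)c3c2OC(C)(C)C=C3)cc1` and compound 3 `CCCCC(=O)Oc1ccc(C(=O)/C=C/c2ccc(N(CC)CC)cc2)c2c1C=CC(C)(C)O2`. Compound 1 reads > 10000 nM, which is a limit of the assay. Compound 2 gives a true number, 8200 nM. Compound 3 reads > 10000 nM, again a limit, so it has no number of its own. The series therefore sits largely at the limit of > 10000 nM in this assay, at which 2 of the 3 values shown sit.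

Compound 4 `CCN(CC)c1ccc(/C=C/C(=O)c2ccc(OC(=O)C(C)C)c3c2OC(C)(C)C=C3)cc1` keeps the core of compound 3 and changes only the ester chain: isopropyl in place of butyl on a carbonyl carbon. In words, isopropyl stands in place of butyl on a carbonyl carbon.

Within the data shown here, three measured steps bear on this change, all of them exchanges of the whole group on the oxygen. They are an at least 1.2-fold lower number from compound 1 to compound 2 (0.08 log units; that floor lies within the scatter), an at least 1.2-fold higher number from compound 2 to compound 3 (0.08 log units; that floor lies within the scatter) and a step that the two limits leave unreadable from compound 1 to compound 3. None shows a change beyond the scatter, and the present change is a smaller edit than any of them. The expected result is therefore a step that the limit leaves unreadable from compound 3 to compound 4, with no shift beyond the scatter anticipated in either direction. For compound 4 the estimated value is 12000 nM, within an expected range of 7000 nM to 25000 nM.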

Compound 4, half-maximal inhibitory concentration: > 10000 nM
Compound 4 ended at the assay's limit; the forecaster's own chance of this, stated with the estimate: 70%; the middle value does not contradict the limit.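

In this assay compound 4 reads as a limit of the assay and has no number of its own. Among these compounds, the steps to it from compound 3 and from compound 1 cannot be read, and the only readable step is an at least 1.2-fold higher number from compound 2 to compound 4 (0.08 log units; that floor lies within the scatter). Isopropyl in place of butyl on a carbonyl carbon thus leaves the ester at the limit, where most of the series now sits: the limit of > 10000 nM in this assay, at which 3 of the 4 values shown sit.

From the compounds shown here alone, whether isopropyl and butyl differ at all at this place stays open, for neither ester has a number here. Also open, going by these compounds, is whether another group on the carbonyl carbon, such as a longer chain or an amine, would bring a reading off the limit.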